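From 3-cyanophenyl to 4-methoxyphenyl: an open step

The compounds below may be only part of what the source reports. "The series", "measured", "known", "first", "only" and "open" are said of these compounds alone.

Measured compounds:
compound 1 `CC/C=C/C(=O)Nc1cccc(Oc2nc(Nc3cccc(C#N)c3)nc3c2CSCC3)c1`: 15900 nM
compound 2 `CCC/C=C/C(=O)Nc1cccc(Oc2nc(Nc3cccc(C#N)c3)nc3c2CSCC3)c1`: 15300 nM
compound 3 `CC(C)/C=C/C(=O)Nc1cccc(Oc2nc(Nc3cccc(C#N)c3)nc3c2CSCC3)c1`: 29600 nM

In a functional assay on MCF7 cells (Homo sapiens) for antiproliferative activity, read by MTT assay, with a stated time of 72 h (on this read-out higher numbers stand for weaker inhibition and lower numbers for stronger inhibition), compound 2 gives 15300 nM, which lies within the scatter of the other two values. Compound 4 `CCC/C=C/C(=O)Nc1cccc(Oc2nc(Nc3ccc(OC)cc3)nc3c2CSCC3)c1` differs from compound 2 as follows: 4-methoxyphenyl in place of 3-cyanophenyl on a nitrogen on an aromatic ring. In words, 4-methoxyphenyl stands in place of 3-cyanophenyl on a nitrogen on an aromatic ring. The measured steps, a 1.0-fold lower number from compound 1 to compound 2 (0.02 log units; within the scatter) and a 1.9-fold higher number from compound 2 to compound 3 (0.29 log units; within the scatter), alter only the chain and stay within the scatter. None of them touches this group, so the data give no direction for the exchange, and compound 2 remains the only anchor. The expected step is a 1.0-fold lower number from compound 2 to compound 4 (0.01 log units; within the scatter), an estimate of no shift beyond the scatter. For compound 4 the estimated value is 15000 nM, with an expected range from 5000 nM to 45000 nM.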

Compound 4, half-maximal inhibitory concentration: > 50000 nM
Compound 4: no number, only a limit; the forecaster's own chance of this, stated with the estimate: 10%; at least 3.3-fold (0.52 log units) between middle value and limit.
By their numbers in this assay, from the lowest: compounds 2, 1 and 3 (each within the scatter of the next). At a limit, above all of these: compound 4.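

In this assay, 4-methoxyphenyl in place of 3-cyanophenyl on this nitrogen gives an at least 3.2-fold higher number from compound 2 to compound 4 (0.51 log units; beyond the scatter). Compound 4 has no number, only a limit of the assay: the limit of > 50000 nM in this assay, at which 1 of the 4 values shown sits. Unlike the chain steps among compound 1, compound 2 and compound 3, which all stay within the scatter, this exchange moves the read-out beyond it, so the group on this nitrogen matters here.

On these data alone, what a 3-methoxyphenyl, a 4-cyanophenyl or a plain phenyl would give on this nitrogen remains open, so the step cannot be divided between the change of group and its place on the ring. Also open, as far as these compounds go, is whether the exchange would act alike with the chain of compound 3.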